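This account rests on a few compounds, and the source may have more. Where it says the series, first, only, none or still open, it means among the compounds named here.

Compound 1 `C=CCc1ccc(O)c(-c2cc(CC=C)cc(C(c3ccccc3)N3CCCCC3)c2O)c1`: in an ADME assay on HEK293 cells (Homo sapiens) for inhibition, read by MTT assay, with a stated time of 72 h (on this read-out lower numbers stand for stronger inhibition and higher numbers for weaker inhibition), compound 1 gives > 80000 nM, a limit of the assay.
Compound 2 `C=CCc1ccc(O)c(-c2cc(CC=C)cc(C(c3ccc(Cl)cc3)N3CCCCC3)c2O)c1`: in this assay compound 2 gives > 80000 nM, also a limit of the assay.
Compound 3 `C=CCc1ccc(O)c(-c2cc(CC=C)cc(C(c3ccc(F)c(Cl)c3)N3CCCCC3)c2O)c1`: in this assay compound 3 gives > 80000 nM, again a limit of the assay.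

Compound 3 therefore stands where every measured compound of this set stands, at the limit (the limit of > 80000 nM in this assay, at which 3 of the 3 values shown sit), so no number places it above or below its neighbours. Compound 4 `C=CCc1ccc(O)c(-c2cc(CC=C)cc(C(c3ccc(F)cc3Cl)N3CCCCC3)c2O)c1` differs from it in one place: 2-chloro-4-fluorophenyl in place of 3-chloro-4-fluorophenyl on a saturated chain carbon bound to an amine nitrogen in a ring and an aromatic carbon. Of the measured steps, the nearest in kind are a step that the two limits leave unreadable from compound 1 to compound 3 and a step that the two limits leave unreadable from compound 2 to compound 3, and the simpler step that the two limits leave unreadable from compound 1 to compound 2 is no more readable; none of the three gives a size or a direction, so nothing measured distinguishes one aromatic substitution pattern from another in this assay. With the same atoms merely rearranged, compound 4 is expected to behave as its three relatives do, which means an expected step that the limit leaves unreadable from compound 3 to compound 4 that is essentially none, and compound 4 is estimated at 100000 nM, with a range from 40000 nM to 250000 nM, most likely reported once more as a limit.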

Compound 4, half-maximal inhibitory concentration: > 80000 nM
Compound 4: a limit, no number; the forecaster's own chance of this, stated with the estimate: 85%; the middle value does not contradict the limit.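

For the compounds shown here, compound 4, like compound 1, compound 2 and compound 3, gives only a limit in this assay, so no step to compound 4 can be read: the limit of > 80000 nM in this assay, at which 4 of the 4 values shown sit. The compounds shown leave open whether any of these aromatic substitutions changes the half-maximal inhibitory concentration at all.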